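The source may report more compounds than this note shows. Statements on the series, on what has been measured and on what is new or still open speak of the compounds shown alone.

Compound 3 `CCn1c(C(=O)NCCN)ccc1C(CC)(CC)c1ccc(OCC(O)C(C)(C)C)c(C)c1` gives 10 nM in an assay on HL-60 cells for agonist activity at vitamin D3 receptor (Homo sapiens), read by microscopy, with a stated time of 96 h (on this read-out higher numbers stand for an effect only at larger amounts of compound and lower numbers for an effect already at smaller amounts), the lowest number among the three measured compounds: compound 2 `CCn1c(C(=O)NCCCN(C)C)ccc1C(CC)(CC)c1ccc(OCC(O)C(C)(C)C)c(C)c1` gives 37 nM and compound 1 `CCOC(=O)CN(C)C(=O)c1ccc(C(CC)(CC)c2ccc(OCC(O)C(C)(C)C)c(C)c2)n1CC` gives 210 nM. The step from compound 3 to compound 4 `CCn1c(C(=O)N(C)c2ccccc2)ccc1C(CC)(CC)c1ccc(OCC(O)C(C)(C)C)c(C)c1` is methyl(phenyl)amino in place of (2-aminoethyl)amino on a carbonyl carbon. Among the compounds with values here, three measured steps bear on it: a 21-fold lower number from compound 1 to compound 3 (1.32 log units; beyond the scatter), a 5.7-fold lower number from compound 1 to compound 2 (0.75 log units; beyond the scatter) and a 3.7-fold lower number from compound 2 to compound 3 (0.57 log units; beyond the scatter). Within the data shown here, compound 1 is the only measured compound whose amide nitrogen carries no hydrogen, and compound 4 likewise carries no hydrogen on that nitrogen, so the step from compound 1 to compound 3 is the closest precedent, read in reverse. A rise in the number is therefore expected for compound 4, of roughly the size seen between compound 1 and compound 3, as a 15-fold higher number from compound 3 to compound 4 (1.18 log units; beyond the scatter). On that basis compound 4 is estimated at 150 nM in this assay, within a range from 40 nM to 600 nM.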

Compound 4, half-maximal effective concentration: 6400 nM
Estimate against measurement, compound 4: 43-fold (1.63 log units) below; measured number outside the range, above it.
By their numbers in this assay, from the lowest: compound 3; then compound 2; then compound 1; then compound 4.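

In this assay, methyl(phenyl)amino on this carbonyl carbon gives larger changes than any earlier step, with a 640-fold higher number from compound 3 to compound 4 (2.81 log units; beyond the scatter) and a 170-fold higher number from compound 2 to compound 4 (2.24 log units; beyond the scatter) against the two amine-bearing amides. The missing amide hydrogen does not alone set the number: the two amides without it stand far apart, with a 30-fold higher number from compound 1 to compound 4 (1.48 log units; beyond the scatter) where phenyl replaces (ethoxycarbonyl)methyl on the amide-type nitrogen. Nothing given here accounts for the size of these rises.

From the compounds shown here alone, it remains open whether the rise follows the phenyl ring itself or its combination with the methyl on that nitrogen, which phenylamino, keeping the amide hydrogen, would help to separate. A benzyl or cyclohexyl group in place of the phenyl would show whether an aromatic ring directly on the nitrogen matters.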